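Dichloropyrimidine Amide in Place of Fluoromethylphenyl Amide

The source may report more compounds than this note shows. Statements on the series, on what has been measured and on what is new or still open speak of the compounds shown alone.

Three amides built on the same core have been measured in a functional assay on A549 cells (Homo sapiens) for antiproliferative activity, read by CCK-8 assay, with a stated time of 72 h; on this read-out lower numbers stand for stronger inhibition and higher numbers for weaker inhibition. Compound 1 `O=C(Nc1cccc(-c2oc3cc(-c4ccc(F)cc4)ccc3c(=O)c2O)c1)c1ccc(F)cc1` gives 6930 nM; compound 2 `COc1ccccc1C(=O)Nc1cccc(-c2oc3cc(-c4ccc(F)cc4)ccc3c(=O)c2O)c1` gives 11700 nM; compound 3 `Cc1cc(C(=O)Nc2cccc(-c3oc4cc(-c5ccc(F)cc5)ccc4c(=O)c3O)c2)ccc1F` gives 11500 nM. Compound 3 thus stands second highest of the three numbers, yet all three lie within the usual scatter of one another: the step of a 1.7-fold higher number from compound 1 to compound 2 (0.23 log units; within the scatter) and the step of a 1.7-fold higher number from compound 1 to compound 3 (0.22 log units; within the scatter) are both small, and the step of a 1.0-fold lower number from compound 2 to compound 3 (0.01 log units; within the scatter) is essentially flat. Compound 4 `O=C(Nc1cccc(-c2oc3cc(-c4ccc(F)cc4)ccc3c(=O)c2O)c1)c1cnc(Cl)nc1Cl` carries the change (2,4-dichloropyrimidin-5-yl in place of 4-fluoro-3-methylphenyl on a carbonyl carbon). Among the measured compounds shown here, the steps that bear on it are those that also swap the group on the carbonyl carbon, namely the step from compound 1 to compound 2 and the step from compound 2 to compound 3, and neither moved the number beyond the scatter. The expected step in this assay from compound 3 to compound 4 is therefore a 1.2-fold lower number from compound 3 to compound 4 (0.06 log units; within the scatter), with no direction claimed. Compound 4 is estimated at 10000 nM, within a range from 4000 nM to 25000 nM.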

Compound 4, half-maximal inhibitory concentration: > 100000 nM
Compound 4 was reported as a limit; the forecaster's own chance of this, stated with the estimate: 10%; middle value at least 10-fold (1.00 log units) from the limit.
By their numbers in this assay, from the lowest: compounds 1, 3 and 2 (each within the scatter of the next). At a limit, above all of these: compound 4.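

In this assay compound 4 is reported only as a limit, not as a number: the limit of > 100000 nM in this assay, at which 1 of the 4 values shown sits. Among the compounds shown here, the group on the carbonyl carbon, which had so far produced only steps within the scatter, now makes a clear difference, with an at least 8.6-fold higher number from compound 3 to compound 4 (0.93 log units; beyond the scatter), an at least 8.5-fold higher number from compound 2 to compound 4 (0.93 log units; beyond the scatter) and an at least 14-fold higher number from compound 1 to compound 4 (1.15 log units; beyond the scatter). This position therefore tolerates the three phenyl groups shown, but not 2,4-dichloropyrimidin-5-yl.

That group brings in its ring nitrogens and its chlorines together, so the compounds shown cannot say which of them goes with the loss of activity. On these data alone, a 2,4-dichlorophenyl group or an unchlorinated pyrimidin-5-yl group on the same carbonyl carbon would separate the two, and the full size of the steps stays unknown while compound 4 remains a limit.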